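Ortho Halogen Swap on an Amide Quinoline Series

The compounds below may be only part of what the source reports. "The series", "measured", "known", "first", "only" and "open" are said of these compounds alone.

The measured compounds:
- Compound 1, `CCN1CCN(c2cc(C)c3cc(NC(=O)c4ccccc4F)ccc3n2)CC1`: 38100 nM
- Compound 2, `CCc1ccccc1C(=O)Nc1ccc2nc(N3CCN(CC)CC3)cc(C)c2c1`: 23900 nM
- Compound 3, `CCN1CCN(c2cc(C)c3cc(NC(=O)c4ccc5ccccc5n4)ccc3n2)CC1`: 3760 nM

All three were tested in a functional assay on SK-BR-3 cells (Homo sapiens) for antiproliferative activity, read by MTT assay, with a stated time of 72 h; a higher number here means a weaker inhibitor, a lower number a stronger inhibitor. Compound 1 has the highest number of the three. Its nearest neighbour is compound 2, reached by a 1.6-fold lower number from compound 1 to compound 2 (0.20 log units; within the scatter), a change that stays within the scatter. Compound 3 lies furthest off, through a 10-fold lower number from compound 1 to compound 3 (1.01 log units; beyond the scatter), and the same carbonyl substituent also drives a 6.4-fold lower number from compound 2 to compound 3 (0.80 log units; beyond the scatter).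

Compound 4, `CCN1CCN(c2cc(C)c3cc(NC(=O)c4ccccc4Cl)ccc3n2)CC1`, has not yet been measured. It differs from compound 1 by chloro in place of fluoro on an aromatic carbon. For the measured compounds named here, the only step that bears on this change is the one from compound 1 to compound 2, which also replaced the fluoro on that aromatic carbon and moved the number little. Compound 4 is therefore expected to sit close to compound 1, with a step of a 1.3-fold lower number from compound 1 to compound 4 (0.10 log units; within the scatter) that is not expected to exceed the scatter. The estimate for compound 4 is 30000 nM, within 12000 nM to 75000 nM.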

Compound 4, half-maximal inhibitory concentration: > 50000 nM
Compound 4: a limit, no number; the forecaster's own chance of this, stated with the estimate: 5%; middle value at least 1.6-fold (0.22 log units) away from the limit.
By their numbers in this assay, from the lowest: compound 3; then compounds 2 and 1 (each within the scatter of the next). At a limit, above all of these: compound 4.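

Compound 4 is held in this assay only by a limit and not by a number: the limit of > 50000 nM in this assay, at which 1 of the 4 values shown sits. On an aromatic carbon ortho to a large group, chloro in place of fluoro gives an at least 1.3-fold higher number from compound 1 to compound 4 (0.11 log units; that floor lies within the scatter), so this floor alone does not separate the two halogens, although the true gap may be wider. The limit does set chloro apart from ethyl on that carbon, with an at least 2.0-fold higher number from compound 2 to compound 4 (0.32 log units; beyond the scatter), and it places the 2-chlorophenyl amide well away from the quinolin-2-yl amide, with an at least 13-fold higher number from compound 3 to compound 4 (1.12 log units; beyond the scatter).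

The compounds shown leave open how far compound 4 lies beyond its limit, and so whether the change from fluoro to chloro has any real size. They also leave open whether a methoxy group, an amine or a carboxylic acid on that aromatic carbon would read nearer to compound 3.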